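The source may report more compounds than this note shows. Statements on the series, on what has been measured and on what is new or still open speak of the compounds shown alone.

Measured so far:
- compound 1, `Nc1cccc(-c2cn3c(-c4ccc(Cl)cc4)csc3n2)c1`: 11000 nM
- compound 2, `COc1ccc(-c2csc3nc(-c4cccc(N)c4)cn23)cc1`: 11000 nM
- compound 3, `C=C(Br)C(=O)Nc1cccc(-c2cn3nc(-c4ccc(OC)cc4)sc3n2)c1`: 890 nM

The read-out throughout is a functional assay on FM3A cells (Mus musculus) for inhibition, read by cell counting, with a stated time of 2 days; on this read-out lower numbers stand for stronger inhibition and higher numbers for weaker inhibition. Compound 2 and compound 1 share a core and differ only in one place, (chloro in place of methoxy on an aromatic carbon); this step gave no change at the digits printed from compound 2 to compound 1 (within the scatter). Compound 3 carries a different core and an acrylamide group on the aniline ring; the difference between its core and that of compound 2 is not broken down here. What the two values show is that compound 3 sits lowest of the three, with compound 1 and compound 2 at the same higher number.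

Compound 4, `C=C(Br)C(=O)Nc1cccc(-c2cn3nc(-c4ccc(Cl)cc4)sc3n2)c1`, is not yet measured. It differs from compound 3 by chloro in place of methoxy on an aromatic carbon, the same change that was made from compound 2 to compound 1. Since that earlier step gave no change at the digits printed from compound 2 to compound 1 (within the scatter), the step from compound 3 to compound 4 is expected to be a 1.0-fold higher number from compound 3 to compound 4 (0.00 log units; within the scatter) in this assay. Compound 4 is accordingly estimated at 900 nM in this assay, with a likely range of 400 nM to 2000 nM.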

Compound 4, half-maximal inhibitory concentration: 2000 nM
Compound 4: the middle estimate sits 2.2-fold (0.35 log units) below what was measured, within the range that was stated.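

In this assay, chloro in place of methoxy on an aromatic carbon gave a 2.2-fold higher number from compound 3 to compound 4 (0.35 log units; beyond the scatter) as a modest step on the second core, whereas the first core had shown no change at the digits printed from compound 2 to compound 1 (within the scatter) for the same change. Set side by side, the two steps cannot be told apart, so the change carries from one core to the other without a measurable difference between them: the same change on two cores in this assay, no change at the digits printed (within the scatter) from compound 2 to compound 1 and a 2.2-fold higher number (0.35 log units; beyond the scatter) from compound 3 to compound 4, 2.2-fold (0.35 log units) apart, within the scatter of two such steps. For the compounds shown here, this rests on only two pairs, however, and it does not show that the change would behave alike on any further core, nor can it separate the effect of the core from that of the acrylamide group, as the two pairs differ in both.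

The compounds shown leave open how an amine, a carboxylic acid or a longer alkoxy chain would read in the place held by methoxy and chloro. They also leave open how much of the gap between the two pairs belongs to the core and how much to the acrylamide group.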